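The source may report more compounds than this note shows. Statements on the series, on what has been measured and on what is new or still open speak of the compounds shown alone.

Measured compounds:
- compound 1, `CC(C)NC(=O)c1c(CN2CCN(C(C)C)CC2)c(-c2ccccc2)nc2ccccc12`: 811 nM in an assay on cell membranes for displacement of a labelled ligand from Substance-K receptor (Homo sapiens); on this read-out lower numbers stand for stronger inhibition and higher numbers for weaker inhibition
- compound 2, `CCC(CC)NC(=O)c1c(CN2CCN(C(C)C)CC2)c(-c2ccccc2)nc2ccccc12`: 18.5 nM in this assay

Going by the values given here, compound 2 holds the lowest of the two numbers in this assay; its only neighbour is compound 1, and the step of a 44-fold lower number from compound 1 to compound 2 (1.64 log units; beyond the scatter) is large and beyond the scatter. Compound 3, `CC(C)N1CCN(Cc2c(-c3ccccc3)nc3ccccc3c2C(=O)NC2CCCCC2)CC1`, has not yet been measured in this assay. It differs from compound 2 by cyclohexyl in place of pentan-3-yl on an amide-type nitrogen. Among the compounds with values here, the one measured step that bears on this place is the change from isopropyl to pentan-3-yl, a 44-fold lower number from compound 1 to compound 2 (1.64 log units; beyond the scatter), where going from a three-carbon to a five-carbon branched group on the amide-type nitrogen lowered the number sharply. Cyclohexyl keeps the branching at the carbon attached to the nitrogen and adds one carbon, so the number for compound 3 is expected to sit near that of compound 2 or somewhat lower, a step of a 1.9-fold lower number from compound 2 to compound 3 (0.27 log units; within the scatter). Compound 3 is thus estimated at 10 nM, within 3 nM to 40 nM.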

Compound 3, inhibition constant: 4.2 nM
For compound 3 the middle estimate is 2.4-fold (0.38 log units) above the measured one; low and high end bracket the measured number.
By their numbers in this assay, from the lowest: compound 3; then compound 2; then compound 1.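

Closing the group on the amide-type nitrogen into a cyclohexyl ring does not give back what the open pentan-3-yl chain had gained in this assay; the number falls further (step: a 4.4-fold lower number from compound 2 to compound 3 (0.64 log units; beyond the scatter)). The whole change from isopropyl to cyclohexyl at this place amounts to a large step (a 190-fold lower number from compound 1 to compound 3 (2.29 log units; beyond the scatter)), so among the three groups shown the order from lowest number is cyclohexyl, pentan-3-yl, isopropyl. Nothing available explains why the ring gives a lower number than the open chain.

The compounds shown leave open whether a cyclopentyl or cycloheptyl ring, or an aromatic phenyl ring, would lower the number further at this nitrogen. They also leave open what a methyl group in place of the amide hydrogen would do.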